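Replacing the Chain Hydroxy with Ethyl in Compound 4

The compounds below may be only part of what the source reports. "The series", "measured", "known", "first", "only" and "open" are said of these compounds alone.

Compound 1, `O=c1cc(Cn2cc(CCO)nn2)c2ccc(O)cc2o1`, a limit: > 100000 nM
Compound 2, `O=c1cc(Cn2cc(CCCO)nn2)c2ccc(O)cc2o1`, a limit: > 100000 nM
Compound 3, `O=c1cc(Cn2cc(CCCCO)nn2)c2ccc(O)cc2o1`, a limit: > 100000 nM

In a functional assay on CFPAC-1 cells (Homo sapiens) for inhibition, read by MTT assay, with a stated time of 72 h (a higher number here means a weaker inhibitor, a lower number a stronger inhibitor), every measured compound sits at the same limit, (the limit of > 100000 nM in this assay, at which 3 of the 3 values shown sit), so compound 3 stands at that limit rather than at a number. Compound 4, `CCCCCCc1cn(Cc2cc(=O)oc3cc(O)ccc23)nn1`, differs from compound 3 by ethyl in place of hydroxy on a saturated chain carbon, four bonds along the chain from an aromatic carbon. For the measured compounds named here, the steps that bear on this change are a step that the two limits leave unreadable from compound 1 to compound 2, a step that the two limits leave unreadable from compound 1 to compound 3 and a step that the two limits leave unreadable from compound 2 to compound 3, and none of them has a readable size, so they give no direction or size to expect in this assay. The most likely outcome is that compound 4 also remains at the limit, and its value is estimated at 80000 nM, within 15000 nM to 400000 nM, which would mean an expected step of an at least 1.2-fold lower number from compound 3 to compound 4 (0.09 log units; that floor lies within the scatter).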

Compound 4, half-maximal inhibitory concentration: > 100000 nM
Compound 4: a limit, no number; the forecaster's own chance of this, stated with the estimate: 60%; middle value at least 1.2-fold (0.09 log units) from the limit.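

No step from compound 1, compound 2 or compound 3 to compound 4 can be read, since all four values are limits rather than numbers: the limit of > 100000 nM in this assay, at which 4 of the 4 values shown sit.

The compounds shown leave open how strongly each one inhibits, and whether changing the chain alters that at all.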